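Swapping the Aryl Group on a Triazole-Linked Oxime Ether

A few compounds are considered here, and "the series" means these few. Any claim that something is new, unique, unknown or untested is made for them only; others in the source may bear on it.

Compound 1 `COc1ccc([C@@H]2C/C(=N/OCc3cn(-c4ccc(Cl)cc4C)nn3)c3cc(CC=C(C)C)c(OC)cc3O2)cc1` is the weaker of the two compounds examined in a functional assay on A549 cells (Homo sapiens) for inhibition, read by sulforhodamine B assay, with a stated time of 48 h, tested at 50 uM (on this read-out lower numbers stand for less inhibition of growth and higher numbers for more inhibition of growth at the one concentration tested), where compound 1 gives 35%. Compound 2 `C#CCOc1ccc([C@@H]2CC(=O)c3cc(CC=C(C)C)c(OC)cc3O2)cc1` sits higher: in this assay compound 2 gives 53%, a gap beyond the scatter. Compound 3 `COc1ccc([C@@H]2C/C(=N/OCc3cn(-c4ccc(NC(C)=O)cc4)nn3)c3cc(CC=C(C)C)c(OC)cc3O2)cc1` keeps the core of compound 1 and differs in one place only: 4-acetamidophenyl in place of 4-chloro-2-methylphenyl on an aromatic nitrogen. Within the data shown here, no pair of measured compounds that differ in a single place is available, so the change has no measured precedent here. The step of a number 3 percentage points lower from compound 1 to compound 3 (within the scatter) is expected to remain within the scatter. The estimate for compound 3 is 32%, between 15% and 50%.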

Compound 3, percent growth inhibition at one concentration: 19%
The estimate for compound 3 lay 13 percentage points above the measured number; the measured number falls inside the stated range.
By their numbers in this assay, from the lowest: compound 3; then compound 1; then compound 2.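

At this place, on an aromatic nitrogen of a five-membered aromatic ring with 3 nitrogen, the aryl group does matter: in this assay, putting 4-acetamidophenyl in place of 4-chloro-2-methylphenyl gives a number 16 percentage points lower from compound 1 to compound 3 (beyond the scatter), with the shared core unchanged. This is the first comparison among these compounds that isolates a single place. No measurement available here accounts for the fall. The compounds shown leave open whether losing the chloro and methyl groups or gaining the acetamide carries the step, and how a phenyl ring bearing an amine or a carboxylic acid would read at this place.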